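Halogen swap on the phenyl carbonyl: bromo to fluoro

The source may report more compounds than this note shows. Statements on the series, on what has been measured and on what is new or still open speak of the compounds shown alone.

Compound 3 `O=C(NCc1cccc(Cn2cnc3ccccc32)c1)c1ccc(Br)cc1` gives 134 nM in an assay for inhibition of Indoleamine 2,3-dioxygenase 1 (Homo sapiens), read by HPLC, with a stated time of 48 h; on this read-out higher numbers stand for weaker inhibition and lower numbers for stronger inhibition. Among the three measured compounds this is the second highest number. Compound 1 `O=C(NCc1cccc(Cn2cnc3ccccc32)c1)c1cc2ccccc2[nH]1` with 72 nM lies nearest, a gap within the scatter. Compound 2 `Cc1ccc(C(=O)NCc2cccc(Cn3cnc4ccccc43)c2)cc1` with 327 nM lies furthest; that gap is a 2.4-fold lower number from compound 2 to compound 3 (0.39 log units; beyond the scatter), beyond the scatter. Compound 4 `O=C(NCc1cccc(Cn2cnc3ccccc32)c1)c1ccc(F)cc1` differs from compound 3 by fluoro in place of bromo on an aromatic carbon. Going by the values given here, no measured step exchanges one halogen for another. Among the compounds with values here, the only step at this position is methyl to bromo, and since a 2.4-fold lower number from compound 2 to compound 3 (0.39 log units; beyond the scatter) was modest, a reversal of similar size rather than a larger shift is the expectation when bromo leaves. Compound 4 is therefore estimated at 250 nM, range 110 nM to 600 nM, an expected 1.9-fold higher number from compound 3 to compound 4 (0.27 log units; within the scatter).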

Compound 4, half-maximal inhibitory concentration: 961 nM
Estimate against measurement, compound 4: 3.8-fold (0.58 log units) below, and the stated range ends below it.
By their numbers in this assay, from the lowest: compounds 1 and 3 (each within the scatter of the next); then compound 2; then compound 4.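

In this assay the identity of the halogen at this aromatic position matters: fluoro in place of bromo gives a large loss (a 7.2-fold higher number from compound 3 to compound 4 (0.86 log units; beyond the scatter)), more than the step between methyl and bromo. Fluoro also falls behind methyl (a 2.9-fold higher number from compound 2 to compound 4 (0.47 log units; beyond the scatter)), and 4-fluorophenyl lies far from 1H-indol-2-yl on the carbonyl carbon (a 13-fold higher number from compound 1 to compound 4 (1.13 log units; beyond the scatter)), so these compounds rank bromo, then methyl, then fluoro. No measured evidence here accounts for this order.

Open, from the compounds shown here alone, is where chloro, iodo or methoxy would fall in that order. Also open, going by these compounds, is whether the order holds with other changes to the shared core.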